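The source may report more compounds than this note shows. Statements on the series, on what has been measured and on what is new or still open speak of the compounds shown alone.

Compound 1 `CCCSc1nc(N/N=C(\C)c2ccccc2O)c2nnn(Cc3ccc(Cl)cc3)c2n1` is a member of a small series examined in a functional assay on ECa-109 cells (Homo sapiens) for antiproliferative activity, read by MTT assay, with a stated time of 72 h; on this read-out lower numbers stand for stronger inhibition and higher numbers for weaker inhibition. In this assay, among the compounds with values here, compound 1 gives 11200 nM, and this is the only value reported as a plain number here. Compound 2 `CCCSc1nc(N/N=C/c2ccc(Cl)cc2)c2nnn(Cc3ccccc3)c2n1` gives > 64000 nM in this assay, which is a limit of the assay and not a number; the limit is where (the limit of > 64000 nM in this assay, at which 1 of the 2 values shown sits). Compound 1 therefore stands alone as the single numerical point, with nothing measured beside it to show how large a change a single substitution brings.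

Compound 3 `CCCSc1nc(N/N=C(\C)c2ccccc2O)c2nnn(Cc3ccc(O)cc3)c2n1` differs from compound 1 in one place: hydroxy in place of chloro on an aromatic carbon. Within the data shown here, no step between two measured compounds of this kind is available, so the expectation rests on the change alone. A step of modest size is expected, in either direction, or none beyond the usual scatter. For compound 3 in this assay the expected value is 12000 nM, with a range from 4000 nM to 40000 nM, which means an expected step of a 1.1-fold higher number from compound 1 to compound 3 (0.03 log units; within the scatter).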

Compound 3, half-maximal inhibitory concentration: 15900 nM
Compound 3: middle estimate off by 1.3-fold (0.12 log units), on the low side; the range from low to high includes it.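

Within the data shown here, this is the first step that can be read between two plain numbers. In this assay, hydroxy in place of chloro gives a 1.4-fold higher number from compound 1 to compound 3 (0.15 log units; within the scatter), so compound 1 and compound 3 cannot be told apart, even though the entering hydroxy brings a hydrogen-bond donor and a hydrogen-bond acceptor that the leaving chloro lacks. At this aromatic carbon, para to a large group, the read-out therefore shows no clear response to this one swap, and nothing measured here bears on why.

As far as these compounds go, whether an amine, a methoxy group or a carboxylic acid on the same carbon would also leave the number within the scatter remains open. This is also the only such pair shown, so it is unknown whether the same swap would read alike on a compound that differs elsewhere.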